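A few compounds are considered here, and "the series" means these few. Any claim that something is new, unique, unknown or untested is made for them only; others in the source may bear on it.

Measured compounds:
compound 1 `CC(C)CC(=O)N1CCN(c2cc(NCCN)c3ccccc3n2)CC1`, in an ADME assay on HEp-2 cells (Homo sapiens) for cytotoxicity, read by CCK-8 assay, with a stated time of 6 days (a higher number here means that more compound is tolerated, a lower number that less compound is tolerated), compound 1 gives > 100000 nM
compound 2 `NCCNc1cc(N2CCN(C(=O)C3(c4ccccc4)CC3)CC2)nc2ccccc12`, in this assay compound 2 gives > 100000 nM

Both values are limits of the assay rather than numbers. For compound 2 the value > 100000 nM is such a limit. The step that the two limits leave unreadable from compound 1 to compound 2 therefore cannot be read in size, since (the limit of > 100000 nM in this assay, at which 2 of the 2 values shown sit). Compound 3 `CCC(=O)N1CCN(c2cc(NCCN)c3ccccc3n2)CC1` differs from compound 2 by ethyl in place of 1-phenylcyclopropyl on a carbonyl carbon. The only measured step bearing on this carbonyl position, from compound 1 to compound 2, was unreadable, and the shared core has shown no toxicity in either case. The estimate for compound 3 is 100000 nM, within 50000 nM to 300000 nM, a step of a number no higher from compound 2 to compound 3 (the limit leaves the size open), most likely reported again only as a limit.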

Compound 3, half-maximal cytotoxic concentration: > 100000 nM
Compound 3 gave a limit, no number; the forecaster's own chance of this, stated with the estimate: 85%; the middle value lies on the limit itself.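

Going by these compounds alone, compound 1, compound 2 and compound 3 all give only a limit, so no step among them can be read in size: the limit of > 100000 nM in this assay, at which 3 of the 3 values shown sit. The compounds shown leave open whether the group on the carbonyl carbon changes how much compound is tolerated in this assay.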